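The source may hold more compounds than are shown below. What is called first, only, known or untested is meant among the compounds shown, and "the series" means these compounds.

Compound 1 `N=C(N)c1cccc(OCC(=O)Nc2ccc(C(=O)N3CCCC3)cc2)c1` serves as the reference point of this small set. Among the compounds with values here, in an assay on isolated protein for inhibition of serine protease 1 (Homo sapiens) (a lower number here means a stronger inhibitor, a higher number a weaker inhibitor), compound 1 gives 2700 nM, the only plain number among the values shown. Compound 2 `N=C(N)c1cccc(OCC(=O)Nc2ccc(C(=O)N3CCCCC3)cc2)c1` carries piperidin-1-yl in place of pyrrolidin-1-yl on the carbonyl carbon. In this assay compound 2 reaches only > 10000 nM, which is a limit of the assay rather than a number. On these data alone, the step of an at least 3.7-fold higher number from compound 1 to compound 2 (0.56 log units; beyond the scatter) lies beyond the scatter, though its full size is unknown because it rests on (the limit of > 10000 nM in this assay, at which 1 of the 2 values shown sits). Compound 3 `N=C(N)c1ccc(O)c(OCC(=O)Nc2ccc(C(=O)N3CCCC3)cc2)c1` differs from compound 1 at another place altogether: hydroxy in place of hydrogen on an aromatic carbon. Within the data shown here, no measured step touches that part of the structure; the one measured step concerns the ring on the carbonyl carbon and says nothing about a hydroxy on the aromatic ring. The expectation for compound 3 in this assay therefore stays near compound 1. Compound 3 is expected to show a 1.1-fold lower number from compound 1 to compound 3 (0.03 log units; within the scatter), nothing clearly beyond the scatter in either direction. Compound 3 is estimated at 2500 nM, with a range from 600 nM to 9000 nM.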

Compound 3, half-maximal inhibitory concentration: 283 nM
Compound 3: the middle estimate sits 8.8-fold (0.95 log units) above what was measured; the measured number lies below the stated range.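

In this assay, within the data shown here, hydroxy in place of hydrogen on an aromatic carbon, ortho to a large group and para to a group of 3 heavy atoms, gives a 9.5-fold lower number from compound 1 to compound 3 (0.98 log units; beyond the scatter), the first step in this set toward a lower number. Among these compounds, it shows that this six-membered aromatic ring is a place where one added heavy atom moves the number beyond the scatter, something the only earlier step could not show, as it concerned the ring on the carbonyl carbon and went toward a higher number. Nothing measured here bears on why the hydroxy has this effect.

The compounds shown leave open whether the step belongs to the hydroxy itself, as a methoxy, an amine or a fluorine on the same aromatic carbon is not among them. They also leave open whether the same hydroxy would lower the number when carried by compound 2, with piperidin-1-yl on the carbonyl carbon, and whether it would do so on another aromatic carbon of that ring.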